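A few compounds are considered here, and "the series" means these few. Any claim that something is new, unique, unknown or untested is made for them only; others in the source may bear on it.

Measured so far:
compound 1 `COc1cc(F)ccc1-c1ccnc2[nH]c(C3CCN(CC(=O)N(C)C)CC3)cc12` — 38 uL/min
compound 2 `CN(C)C(=O)CN1CCC(c2cc3c(-c4ccc(=O)n(CCC5CCOCC5)c4)ccnc3[nH]2)CC1` — 14 uL/min
compound 3 `CC(C)n1cc(-c2ccnc3[nH]c(C4CCN(CC(=O)N5CCCCC5)CC4)cc23)ccc1=O` — 26 uL/min

In an ADME assay on cells (Hepatocyte, Rattus norvegicus) for metabolic stability (on this read-out higher numbers stand for fast clearance and lower numbers for slow clearance), compound 3 stands second highest of the three numbers, yet its gaps to compound 1 and to compound 2 both fall within the usual scatter of this kind of measurement, so the three compounds cannot be told apart on this read-out. Compound 4 `CC(C)n1cc(-c2ccnc3[nH]c(C4CCN(Cc5cccs5)CC4)cc23)ccc1=O` is compound 3 with a single change: thiophen-2-yl in place of (piperidin-1-yl)carbonyl on a saturated chain carbon bound to an amine nitrogen in a ring. No measured pair among these compounds shares that change, so the numbers give no direct guide. The step is expected to run upward by a moderate amount, a 2.3-fold higher number from compound 3 to compound 4 (0.36 log units; beyond the scatter), although a result inside the scatter would not be surprising. Compound 4 is therefore estimated at 60 uL/min, with a likely range from 25 uL/min to 150 uL/min.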

Compound 4, intrinsic clearance in a liver preparation (reported as CLH), per the amount of preparation that the assay uses: 43 uL/min
Beside the measured number, compound 4's estimate is 1.4-fold (0.14 log units) above it, within the range that was stated.
By their numbers in this assay, from the lowest: compounds 2, 3, 1 and 4 (each within the scatter of the next, the first and the last beyond it).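

In this assay, having thiophen-2-yl in place of (piperidin-1-yl)carbonyl on a saturated chain carbon bound to an amine nitrogen in a ring gives a 1.7-fold higher number from compound 3 to compound 4 (0.22 log units; within the scatter). This first step at this position shows that an aromatic five-membered ring and the larger amide group can give clearance numbers that cannot be told apart. No available evidence bears on this result. A phenyl ring or a carboxylic acid at this place remains an open case. As far as these compounds go, whether the same replacement would give a similar step on a different core also remains open.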